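The source may hold more compounds than are shown below. What is called first, only, known or untested is meant among the compounds shown, and "the series" means these compounds.

The three measured compounds share one core and were all tested in a functional assay on CHO-K1 cells for antagonist activity at Orexin/Hypocretin receptor type 1 (Homo sapiens), read by FLIPR and calcium flux; a lower number here means a stronger inhibitor, a higher number a weaker inhibitor. Compound 1 `CCOC(=O)c1ccccc1C(=O)N1C[C@H](Oc2cc(C#N)ccn2)CC[C@H]1C` gives 7100 nM. Going by the values given here, compound 2 `CC(C)OC(=O)c1ccccc1C(=O)N1C[C@H](Oc2cc(C#N)ccn2)CC[C@H]1C` gives 3300 nM, and the one step between measured compounds that differ in a single place is a 2.2-fold lower number from compound 1 to compound 2 (0.33 log units; beyond the scatter). Compound 3 `C#Cc1ccnc(O[C@@H]2CC[C@@H](C)N(C(=O)c3ccccc3-n3nccn3)C2)c1` gives 240 nM in this assay, the lowest of the three numbers; the nearest to it is compound 2, the furthest compound 1, and both gaps lie beyond the scatter.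

Compound 4 `C[C@@H]1CC[C@@H](Oc2cc(Br)ccn2)CN1C(=O)c1ccccc1-n1nccn1` differs from compound 3 by bromo in place of ethynyl on an aromatic carbon. Among the compounds with values here, no measured step touches this position: the only step known is the one from compound 1 to compound 2, which concerns a different part of the molecule and says nothing about the (4-ethynylpyridin-2-yl)oxy end. With no guidance, a step of a 1.3-fold higher number from compound 3 to compound 4 (0.10 log units; within the scatter) is expected in this assay, none beyond the scatter. The estimate rests on compound 3 at 240 nM. Compound 4 is therefore estimated at 300 nM, with a range from 90 nM to 1000 nM.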

Compound 4, half-maximal inhibitory concentration: 380 nM
Compound 4: middle estimate off by 1.3-fold (0.10 log units), on the low side; low and high end bracket the measured number.
By their numbers in this assay, from the lowest: compounds 3 and 4 (each within the scatter of the next); then compound 2; then compound 1.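

Going by these compounds alone, at the aromatic carbon opposite the ring nitrogen, the first measured change in this assay is a 1.6-fold higher number from compound 3 to compound 4 (0.20 log units; within the scatter) and thus leaves bromo and ethynyl within the scatter of each other. Within this pair, then, the triple bond of ethynyl is not needed for a number of this order, and a single bromine atom in its place gives a reading that cannot be told apart from it. Nothing measured here bears on why the two groups read alike.

Going by these compounds, whether a smaller group such as chloro or methyl, or an amine or methoxy group, would also stay within the scatter at this position remains open. The nitrile at this position occurs only in compound 1 and compound 2, which also differ from compound 3 in the rest of the molecule, so its place among these groups also remains open.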